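Phenyl in place of thiophen-3-yl on a weakly active core

This account rests on a few compounds, and the source may have more. Where it says the series, first, only, none or still open, it means among the compounds named here.

Compound 1 `Nc1nc(N)c2c(-c3ccsc3)cn([C@@H]3O[C@H](CO)[C@@H](O)[C@H]3O)c2n1`: in a functional assay on CEM-DNR-bulk cells (Homo sapiens), read by MTT assay, with a stated time of 72 h (on this read-out lower numbers stand for stronger inhibition and higher numbers for weaker inhibition), compound 1 gives > 20000 nM, which is a limit of the assay and not a number.
Compound 2 `COc1ncnc2c1c(-c1cccs1)cn2[C@@H]1O[C@H](CO)[C@@H](O)[C@H]1O`: in this assay compound 2 gives 12100 nM.
Compound 3 `Cc1nc(N)c2c(-c3ccsc3)cn([C@@H]3O[C@H](CO)[C@@H](O)[C@H]3O)c2n1`: in this assay compound 3 gives > 20000 nM, again a limit of the assay.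

Among the measured compounds shown here, compound 1 thus stands at the edge of what this assay can report, and the limit of > 20000 nM in this assay, at which 2 of the 3 values shown sit, shows that it shares this position with compound 3; only compound 2 carries a number, and compound 2 differs from compound 1 in more than one place, so no single step leads from it to compound 1. For the measured compounds named here, the sole one-place step among the measured compounds is a step that the two limits leave unreadable from compound 1 to compound 3, and because both of its ends are limits, the limit of > 20000 nM in this assay, at which 2 of the 3 values shown sit, leaves its size unreadable.

Compound 4 `Nc1nc(N)c2c(-c3ccccc3)cn([C@@H]3O[C@H](CO)[C@@H](O)[C@H]3O)c2n1` differs from compound 1 in one place: phenyl in place of thiophen-3-yl on an aromatic carbon. Going by the values given here, no measured step touches the group on that aromatic carbon, and the only measured step, a step that the two limits leave unreadable from compound 1 to compound 3, gives no size to lean on. The account therefore expects no step beyond the scatter, written as a step that the limit leaves unreadable from compound 1 to compound 4, and estimates compound 4 at 25000 nM, within 8000 nM to 80000 nM, with a fair chance that this assay again reports only a limit.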

Compound 4, half-maximal inhibitory concentration: > 20000 nM
Compound 4: a limit, no number; the forecaster's own chance of this, stated with the estimate: 65%; the middle value is on the limit's open side.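

In this assay compound 4 gives > 20000 nM, a limit of the assay and not a number. Compound 1 also stands at a limit, so no step from it to compound 4 can be read: the limit of > 20000 nM in this assay, at which 3 of the 4 values shown sit.

The compounds shown leave open whether phenyl and thiophen-3-yl differ at all on the shared core in this assay.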